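Swapping the pyridinyl on the piperazine for fluorophenyl

A few compounds are considered here, and "the series" means these few. Any claim that something is new, unique, unknown or untested is made for them only; others in the source may bear on it.

Of the compounds shown here, three sharing one core have been tested in a functional assay on HeLa cells (Homo sapiens) for antiproliferative activity, read by CCK-8 assay, with a stated time of 72 h, tested at 2 uM; a lower number here means a weaker effect, a higher number a stronger effect of the compound at the concentration tested. Compound 1 `Nc1ccccc1NC(=O)c1ccc(CSC(=S)N2CCc3ccccc32)cc1` gives 38%. Among the compounds with values here, compound 3 `CCN(Cc1ccncc1)C(=S)SCc1ccc(C(=O)Nc2ccccc2N)cc1` gives 63.5%, and the only single-point step, a number 25.5 percentage points higher from compound 1 to compound 3 (beyond the scatter), concerns the group on the thiocarbonyl carbon. Compound 2 `Nc1ccccc1NC(=O)c1ccc(CSC(=S)N2CCN(c3cccnc3)CC2)cc1` gives 66.2%, a number within the scatter of compound 3 and beyond the scatter above compound 1. Compound 4 `Nc1ccccc1NC(=O)c1ccc(CSC(=S)N2CCN(c3ccccc3F)CC2)cc1` differs from compound 2 by 2-fluorophenyl in place of pyridin-3-yl on an amine nitrogen in a ring. Within the data shown here, no measured step changes the group on that ring nitrogen, so there is no direct guide. Compound 4 is therefore expected to land near compound 2, with a number 6.2 percentage points lower from compound 2 to compound 4 (within the scatter) as the estimated step. The estimate for compound 4 in this assay is 60%, between 40% and 78%.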

Compound 4, a percentage reported as inhibition, at one concentration (the size of the read-out at that concentration, not a potency): 17.5%
Estimate against measurement, compound 4: 42.5 percentage points above, outside the stated range (below it).
By their numbers in this assay, from the lowest: compound 4; then compound 1; then compounds 3 and 2 (each within the scatter of the next).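

In this assay, within the data shown here, the group on this amine nitrogen in a ring proves decisive: 2-fluorophenyl in place of pyridin-3-yl gives a number 48.7 percentage points lower from compound 2 to compound 4 (beyond the scatter), whereas the earlier compounds showed an effect only at the thiocarbonyl carbon. The change removes the pyridine nitrogen and adds a fluorine together, so this single step cannot separate the two. Nothing available explains the drop. Going by these compounds, a plain phenyl on the same nitrogen would show whether losing the pyridine nitrogen or gaining the fluorine matters more, and this remains open.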